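Working notes: compound 3 to compound 4

This account rests on a few compounds, and the source may have more. Where it says the series, first, only, none or still open, it means among the compounds named here.

Values in a functional assay on HT-29 cells (Homo sapiens) for antiproliferative activity, read by sulforhodamine B assay, with a stated time of 48 h (a higher number here means a weaker inhibitor, a lower number a stronger inhibitor), for the series
compound 1 `COc1cccc(OS(=O)(=O)c2ccc(N3CCN(C)C3=O)cc2)c1` gives 2500 nM
compound 2 `CCCN1CCN(c2ccc(S(=O)(=O)Oc3cccc(OC)c3)cc2)C1=O` gives 25000 nM
compound 3 `CCCCN1CCN(c2ccc(S(=O)(=O)Oc3ccccc3OC)cc2)C1=O` gives > 100000 nM as a limit
compound 4 `CCCCN1CCN(c2ccc(S(=O)(=O)Oc3cccc(OC)c3)cc2)C1=O` is not yet measured

Compound 3 gives > 100000 nM and this is a limit of this assay, not a number. The change to compound 4 is 3-methoxyphenyl in place of 2-methoxyphenyl on an oxygen. Within the data shown here, the one measured step of a 10-fold higher number from compound 1 to compound 2 (1.00 log units; beyond the scatter) lies on the chain and not at that oxygen, so it bears on this change only indirectly, and no measured step covers the change itself. It does suggest that the butyl chain of compound 4 will keep the number high. Compound 1 (2500 nM) and compound 2 (25000 nM) both carry 3-methoxyphenyl on the oxygen and both give numbers, so a move to a lower number is expected, of modest and uncertain size. The estimated change is an at least 2.8-fold lower number from compound 3 to compound 4 (0.45 log units; beyond the scatter) and it starts from a limit. The estimated value for compound 4 is 35000 nM and the expected range runs from 10000 nM to 100000 nM in this assay.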

Compound 4, half-maximal inhibitory concentration: 13000 nM
Estimate against measurement, compound 4: 2.7-fold (0.43 log units) above; low and high end bracket the measured number.
By their numbers in this assay, from the lowest: compound 1; then compounds 4 and 2 (each within the scatter of the next). At a limit, above all of these: compound 3.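

In this assay compound 3 sits at a limit of the assay and not at a number: the limit of > 100000 nM in this assay, at which 1 of the 4 values shown sits.

Among these compounds, with the butyl chain held, the only measured step at this position reads an at least 7.6-fold lower number from compound 3 to compound 4 (0.88 log units; beyond the scatter) and, starting from that limit, its full size stays unknown. On the chain, the reading a 1.9-fold lower number from compound 2 to compound 4 (0.28 log units; within the scatter) does not separate propyl from butyl, while the methyl chain stays apart from butyl in the reading a 5.2-fold higher number from compound 1 to compound 4 (0.72 log units; beyond the scatter).

From the compounds shown here alone, only the butyl chain carries both methoxyphenyl groups, so whether the step on the oxygen holds with methyl or propyl remains open. Also open, going by these compounds, is how a phenyl bearing an amine or a carboxylic acid on that oxygen would read, and how a chain longer than butyl would.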